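Carbamoyl in Place of Ethyl on a Stilbene-like Scaffold

This account rests on a few compounds, and the source may have more. Where it says the series, first, only, none or still open, it means among the compounds named here.

Compound 1, `CC=C(c1cc(OC)cc(OC)c1)c1ccc(OC)c(OC)c1`: 480 nM
Compound 2, `COc1cc(OC)cc(C(=CC(C)=O)c2ccc(OC)c(OC)c2)c1`: > 10000 nM
Compound 3, `CCC=C(c1cc(OC)cc(OC)c1)c1ccc(OC)c(OC)c1`: > 10000 nM

In a functional assay on HCT-116 cells (Homo sapiens) for cytotoxicity, read by scintillation counting and thymidine incorporation, with a stated time of 72 h (on this read-out lower numbers stand for stronger inhibition and higher numbers for weaker inhibition), compound 1 gives 480 nM. Compound 2 reaches only a limit of the assay, > 10000 nM. Compound 3 likewise reaches only a limit, > 10000 nM. Compound 3 therefore stands at the weak end of what is shown, and the limit of > 10000 nM in this assay, at which 2 of the 3 values shown sit, marks that two of the three values sit there. The step to compound 4, `COc1cc(OC)cc(C(=CC(N)=O)c2ccc(OC)c(OC)c2)c1`, is carbamoyl in place of ethyl on a double-bonded chain carbon bound to a double-bonded chain carbon. Among the measured compounds shown here, two measured steps bear on it. an at least 20-fold higher number from compound 1 to compound 2 (1.31 log units; beyond the scatter), where a carbonyl-bearing group enters on the same double-bonded chain carbon. a step that the two limits leave unreadable from compound 2 to compound 3, so the swap between acetyl and ethyl cannot be sized. Since compound 2 with acetyl sits at the limit > 10000 nM and compound 3 with ethyl sits at the limit > 10000 nM, compound 4 with carbamoyl is expected to remain at the limit as well, with a step that the limit leaves unreadable from compound 3 to compound 4 estimated as no readable step. Compound 4 is expected to give about 15000 nM, within 5000 nM to 50000 nM.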

Compound 4, half-maximal inhibitory concentration: > 10000 nM
Compound 4: only a limit was reported; the forecaster's own chance of this, stated with the estimate: 80%; the middle value does not contradict the limit.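

In this assay, the change to carbamoyl gives an at least 20-fold higher number from compound 1 to compound 4 (1.31 log units; beyond the scatter), so carbamoyl, with its hydrogen-bond donor, joins acetyl and ethyl in losing the readable value of compound 1. The steps to compound 4 from compound 2 and from compound 3 cannot be read, and carbamoyl, acetyl and ethyl therefore cannot be ranked against one another: the limit of > 10000 nM in this assay, at which 3 of the 4 values shown sit. Among the four compounds, only compound 1, with methyl, gives a number rather than a limit, and no compound shown goes against this.

On these data alone, how far the true values of compound 2, compound 3 and compound 4 lie past that limit remains open. Also open, as far as these compounds go, is whether hydrogen, an amine or a carboxylic acid on this double-bonded chain carbon would give a readable value.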